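Swapping a fused aromatic ring for a chlorophenyl thioether

This account rests on a few compounds, and the source may have more. Where it says the series, first, only, none or still open, it means among the compounds named here.

Among the compounds with values here, compound 3 `Cc1cc(-n2ccc3cccnc32)c2ncc(CSCCc3ccccc3)n2c1` is one of three compounds measured in an ADME assay on HEL cells (Homo sapiens) for cytotoxicity, with a stated time of 3 days; on this read-out higher numbers stand for lower toxicity in this test and lower numbers for higher toxicity in this test. In this assay compound 3 gives 100 ug/mL, level with compound 1 `Cc1cc(-c2ccoc2)c2ncc(CSCCc3ccccc3)n2c1`, which gives 100 ug/mL. Compound 2 `Cc1cc(N2CCCC2=O)c2ncc(CSCCc3ccccc3)n2c1` gives 20 ug/mL, and a 5.0-fold higher number from compound 2 to compound 3 (0.70 log units; beyond the scatter) lies beyond the scatter. Both measured steps touch the same position on the shared core and therefore bear on the change considered here. no change at the digits printed from compound 1 to compound 3 (within the scatter) shows that exchanging one aromatic ring for a larger aromatic ring system left the number unchanged, whereas a 5.0-fold higher number from compound 2 to compound 3 (0.70 log units; beyond the scatter) shows that the only non-aromatic ring in the set, the 2-oxopyrrolidin-1-yl group of compound 2, went together with a lower number.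

Compound 4 `Cc1cc(Sc2ccc(Cl)cc2)c2ncc(CSCCc3ccccc3)n2c1` has not yet been measured. a group of 8 heavy atoms (6 carbon, 1 sulfur, 1 chlorine; one six-membered aromatic ring of carbon only) in place of a group of 9 heavy atoms (7 carbon, 2 nitrogen; one five-membered aromatic ring with 1 hetero atom, one six-membered aromatic ring with 1 hetero atom), on an aromatic carbon The entering group once more carries an aromatic ring, here joined to the core through sulfur. Because no change at the digits printed from compound 1 to compound 3 (within the scatter) shows that an aromatic-for-aromatic exchange at this position produced no change, the step expected for compound 4 is no change at the digits printed from compound 3 to compound 4 (within the scatter), that is, none beyond the scatter. The estimate for compound 4 in this assay is therefore 100 ug/mL, with a range from 20 ug/mL to 100 ug/mL, the lower end allowing for a drop like that seen with compound 2.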

Compound 4, minimum cytotoxic concentration: 4 ug/mL
Estimate against measurement, compound 4: 25-fold (1.40 log units) above; the measured number lies below the stated range.
By their numbers in this assay, from the lowest: compound 4; then compound 2; then compounds 1 and 3 (each within the scatter of the next).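

In this assay, an aromatic ring in the entering group is not enough to hold the number at this position: compound 4 carries one, yet the change from the fused aromatic group shows a 25-fold lower number from compound 3 to compound 4 (1.40 log units; beyond the scatter), and the change from furan-3-yl shows a 25-fold lower number from compound 1 to compound 4 (1.40 log units; beyond the scatter). The earlier split between aromatic groups with high numbers and a non-aromatic group with a lower one therefore does not hold, and compound 4 is the compound that goes against it. The 2-oxopyrrolidin-1-yl group also no longer marks the low end of the set, as there is a 5.0-fold lower number from compound 2 to compound 4 (0.70 log units; beyond the scatter), which shows that this position can reach higher toxicity in this test than compound 2 had indicated.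

The (4-chlorophenyl)sulfanyl group brings a sulfur link and a chlorine together, and the compounds shown cannot separate them; a plain phenylsulfanyl group, or a 4-chlorophenyl group joined directly to the core, would tell the two apart. Nothing measured here accounts for the drop seen with compound 4.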